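The compounds below may be only part of what the source reports. "The series", "measured", "known", "first", "only" and "open" are said of these compounds alone.

In a functional assay on MCF7 cells (Homo sapiens) for inhibition, read by MTT assay, with a stated time of 72 h (a higher number here means a weaker inhibitor, a lower number a stronger inhibitor), compound 3 `Cc1cc2occ(-c3nc(-c4ccccc4)c(-c4ccccc4)n3-c3cccc([N+](=O)[O-])c3)c(=O)c2cc1Cl` gives 1560 nM. Within the data shown here, compound 1 `Cc1cc2occ(-c3nc(-c4ccccc4)c(-c4ccccc4)n3-c3ccc(Cl)c(Cl)c3)c(=O)c2cc1Cl` gives 1560 nM, level with it, and these two share the lowest number of the three measured so far. Compound 2 `Cc1ccc(-n2c(-c3coc4cc(C)c(Cl)cc4c3=O)nc(-c3ccccc3)c2-c2ccccc2)c(C)c1` gives 6250 nM.

These compounds differ only in the phenyl group on an aromatic nitrogen. Compound 4 `COc1cccc(-n2c(-c3coc4cc(C)c(Cl)cc4c3=O)nc(-c3ccccc3)c2-c2ccccc2)c1` changes that group again, with methoxy in place of nitro on an aromatic carbon, meta to a large group: methoxy in place of nitro on an aromatic carbon.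

Among the measured compounds shown here, no measured step makes this exact swap, so the nearest steps only set a scale. Replacing 3,4-dichlorophenyl with 3-nitrophenyl gave no change at the digits printed from compound 1 to compound 3 (within the scatter). Replacing 3,4-dichlorophenyl with 2,4-dimethylphenyl gave a 4.0-fold higher number from compound 1 to compound 2 (0.60 log units; beyond the scatter), and replacing 2,4-dimethylphenyl with 3-nitrophenyl gave a 4.0-fold lower number from compound 2 to compound 3 (0.60 log units; beyond the scatter).

For the measured compounds named here, the only measured group without chlorine or nitro is in compound 2, at 6250 nM. A small step towards a higher number is therefore expected, estimated as a 2.1-fold higher number from compound 3 to compound 4 (0.31 log units; beyond the scatter). For compound 4 the estimated value is 3200 nM, with an expected range of 1300 nM to 7500 nM.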

Compound 4, half-maximal inhibitory concentration: 25000 nM
Estimate against measurement, compound 4: 7.8-fold (0.89 log units) below, outside the stated range (above it).
By their numbers in this assay, from the lowest: compounds 1 and 3 (each within the scatter of the next); then compound 2; then compound 4.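

Among these compounds, at this place on the ring, meta to a large group, methoxy in place of nitro gives a 16-fold higher number from compound 3 to compound 4 (1.20 log units; beyond the scatter) in this assay, so one small group can matter far more than the earlier steps suggested. The 3-methoxyphenyl group also falls behind the other two groups, with a 4.0-fold higher number from compound 2 to compound 4 (0.60 log units; beyond the scatter) and a 16-fold higher number from compound 1 to compound 4 (1.20 log units; beyond the scatter), which makes compound 4 the weakest inhibitor of the four. Among the compounds shown here, nothing available explains why this swap moves the number so far.

As far as these compounds go, it remains open how other groups at this place would read, such as an amine or a carboxylic acid, and whether a longer chain in place of methoxy would sit nearer compound 3 or compound 4. From the compounds shown here alone, it is also open whether the same swap would have a similar effect with a different group elsewhere on the core.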